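A few compounds are considered here, and "the series" means these few. Any claim that something is new, unique, unknown or untested is made for them only; others in the source may bear on it.

Within the data shown here, compound 1 `CONC(=O)[C@@H]1CC=C(CCC=C(C)C)C[C@H]1c1ccccc1` is the only compound of this small set with a number in an assay on isolated protein for inhibition of Apoptosis regulator Bcl-2 (Homo sapiens), read by fluorescence polarization, with stated times of 5 min and 10 min; on this read-out lower numbers stand for stronger inhibition and higher numbers for weaker inhibition: compound 1 gives 2700 nM. Compound 2 `CC(C)=CCCC1=CC[C@H](C(=O)N(C)C)[C@@H](c2ccccc2)C1`, which carries a dimethylamide in place of the methoxyamide, reaches only the limit of this assay, compound 2 giving > 23000 nM. Among the measured compounds shown here, that limit is the line (the limit of > 23000 nM in this assay, at which 1 of the 2 values shown sits), so the set holds one number and one limit, and no step between measured compounds can be sized.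

Compound 3 `CC(C)=CCCC1=CC[C@@H](C(=O)NCCC(=O)O)[C@H](c2ccccc2)C1` differs from compound 1 by 2-carboxyethyl in place of methoxy on an amide-type nitrogen. Here 2-carboxyethyl in place of methoxy on an amide-type nitrogen is compared without any measured precedent in this assay. Compound 3 is therefore expected to sit near compound 1, with a step of a 1.4-fold lower number from compound 1 to compound 3 (0.13 log units; within the scatter) that would not clearly exceed the usual scatter. Compound 3 is estimated at 2000 nM, with a range from 500 nM to 8000 nM.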

Compound 3, inhibition constant: > 23000 nM
Compound 3 was reported as a limit; the forecaster's own chance of this, stated with the estimate: 20%; middle value at least 11-fold (1.06 log units) from the limit.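

Among these compounds, replacing methoxy with 2-carboxyethyl on the amide-type nitrogen gives an at least 8.5-fold higher number from compound 1 to compound 3 (0.93 log units; beyond the scatter) in this assay, the first sized step at this position. With compound 3 as well as compound 2 at a limit, the methoxyamide of compound 1 is the only one of the three groups shown here that gives a number. The limit of compound 3 means the step has a lower bound but no full size, and the set now rests largely on that limit: the limit of > 23000 nM in this assay, at which 2 of the 3 values shown sit.

On these data alone, how far compound 2 and compound 3 lie past the limit stays open, so they cannot be ranked against each other. As far as these compounds go, it is also open whether an ethoxy group, a methyl ester of the carboxylic acid or a chain ending in an amine on this nitrogen would give a number.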